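Chloro for methyl on a furan and a phenyl

This account rests on a few compounds, and the source may have more. Where it says the series, first, only, none or still open, it means among the compounds named here.

Compound 1 `COc1ccc(CNC(=O)/C(C#N)=C/c2ccc(C)o2)cc1`: 29000 nM
Compound 2 `COc1ccc(CNC(=O)/C(C#N)=C/c2ccc(Cl)o2)cc1`: 13000 nM
Compound 3 `COc1ccc(CNC(=O)/C(C#N)=C/c2ccc(C)cc2)cc1`: 34000 nM

Of the compounds shown here, three have been tested in a functional assay on SW480 cells (Homo sapiens) for inhibition, read by MTT assay, with a stated time of 72 h; on this read-out higher numbers stand for weaker inhibition of growth and lower numbers for stronger inhibition of growth. Compound 1 `COc1ccc(CNC(=O)/C(C#N)=C/c2ccc(C)o2)cc1` gives 29000 nM in this assay, compound 2 `COc1ccc(CNC(=O)/C(C#N)=C/c2ccc(Cl)o2)cc1` gives 13000 nM, and compound 3 `COc1ccc(CNC(=O)/C(C#N)=C/c2ccc(C)cc2)cc1` gives 34000 nM. The two cores differ as follows: 4-methylphenyl in place of 5-methylfuran-2-yl on a double-bonded chain carbon bound to a double-bonded chain carbon; this step gives a 1.2-fold higher number from compound 1 to compound 3 (0.07 log units; within the scatter), so the two cores stand close in this assay. Between compound 2 and compound 3 the step is a 2.6-fold higher number from compound 2 to compound 3 (0.42 log units; beyond the scatter).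

The change from compound 1 to compound 2 is chloro in place of methyl on an aromatic carbon. It brought a 2.2-fold lower number from compound 1 to compound 2 (0.35 log units; beyond the scatter), a modest gain in growth inhibition. Compound 4 `COc1ccc(CNC(=O)/C(C#N)=C/c2ccc(Cl)cc2)cc1` is the not yet measured partner of compound 3, and the change from compound 3 to compound 4 is chloro in place of methyl on an aromatic carbon. The change is of the same kind, but not the same: in compound 2 the chloro sits on a five-membered aromatic ring with one oxygen, next to the ring oxygen, whereas in compound 4 it sits on a six-membered aromatic ring of carbon only, para to a large group. Among the measured compounds shown here, since only one earlier example of this kind exists, and on a different ring, the expected step from compound 3 to compound 4 is a 1.9-fold lower number from compound 3 to compound 4 (0.28 log units; within the scatter), somewhat smaller than the measured one, with wide uncertainty. Compound 4 is therefore estimated at 18000 nM in this assay, with a likely range from 8000 nM to 40000 nM.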

Compound 4, concentration for 50% growth inhibition: 10000 nM
Estimate against measurement, compound 4: 1.8-fold (0.26 log units) above, and the stated range covers the measured number.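

In this assay, chloro in place of methyl on the six-membered ring gives a 3.4-fold lower number from compound 3 to compound 4 (0.53 log units; beyond the scatter), so the change carried from the core of compound 1 to the core of compound 3 in the same direction, and the two steps agree in size within the scatter: the same change on two cores in this assay, a 2.2-fold lower number (0.35 log units; beyond the scatter) from compound 1 to compound 2 and a 3.4-fold lower number (0.53 log units; beyond the scatter) from compound 3 to compound 4, 1.5-fold (0.18 log units) apart, within the scatter of two such steps

With chloro on both cores, the exchange of the ring gives a 1.3-fold lower number from compound 2 to compound 4 (0.11 log units; within the scatter), which is within the scatter, so the core made little difference with chloro, just as it did with methyl, while the exchange of the whole substituted ring gives a 2.9-fold lower number from compound 1 to compound 4 (0.46 log units; beyond the scatter). Among the compounds shown here, this rests on only two matched pairs in a single cell line, so it does not show that the change would carry to further cores or to other cells, and it gives no explanation for the shift in growth inhibition.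

The compounds shown leave open whether bromo, fluoro, trifluoromethyl or methoxy at the same place would follow chloro or methyl. They also leave open how the series would respond if the nitrile gave way to a carboxylic acid or an ester, since the rest of the shared core stays the same throughout.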